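This account rests on a few compounds, and the source may have more. Where it says the series, first, only, none or still open, it means among the compounds named here.

In a functional assay on HOS cells (Homo sapiens) for antiproliferative activity, read by sulforhodamine B assay (on this read-out higher numbers stand for weaker inhibition of growth and lower numbers for stronger inhibition of growth), compound 1 (`CC(=O)O[C@@H]1[C@@H](OCc2ccccc2)[C@H](OCc2ccccc2)[C@@H](COCc2ccccc2)O[C@H]1C`) gives 8800 nM. Compound 2 (`CC[C@H]1O[C@H](COCc2ccccc2)[C@@H](OCc2ccccc2)[C@H](OCc2ccccc2)[C@H]1O`) is recorded at > 50000 nM, which is a limit of the assay and not a number. Compound 3 (`CCC[C@@H]1O[C@H](COCc2ccc(F)cc2)[C@@H](OCc2ccc(F)cc2)[C@H](OCc2ccc(F)cc2)[C@H]1O`) gives 17200 nM, and this value lies within the scatter of the value for compound 1. Compound 4 (`CCC[C@H]1O[C@H](COCc2ccc(F)cc2)[C@@H](OCc2ccc(F)cc2)[C@H](OCc2ccc(F)cc2)[C@H]1O`) has the same atoms and bonds as compound 3: the two compounds have the same atoms and bonds and differ only in configuration as drawn: 1 of 5 stereo elements differ; a stereocentre at a saturated ring carbon is drawn S in compound 3 and R in compound 4. A stereocentre at a saturated ring carbon is drawn S in compound 3 and R in compound 4. Among the compounds with values here, no measured pair isolates such a change, so the expected 1.2-fold higher number from compound 3 to compound 4 (0.07 log units; within the scatter) in this assay is none beyond the scatter, in neither direction. For compound 4 the estimated value is 20000 nM, with an expected range of 7000 nM to 50000 nM.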

Compound 4, concentration for 50% growth inhibition: > 50000 nM
Compound 4: only a limit was reported (the forecaster's own chance of this, stated with the estimate: 20%); at least 2.5-fold (0.39 log units) between middle value and limit.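

In this assay, a change of configuration alone, from S to R at a saturated ring carbon, gives an at least 2.9-fold higher number from compound 3 to compound 4 (0.46 log units; beyond the scatter). Within the data shown here, this is the first pair here to isolate such a change, and its step lies beyond the scatter, so the drawn configuration at this position separates the two compounds. The full size of the step cannot be read, since the value for compound 4 is a limit and not a number: the limit of > 50000 nM in this assay, at which 2 of the 4 values shown sit.

On these data alone, whether this configuration would count equally in compounds carrying a longer chain or an amine on the shared core remains open.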